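The source may hold more compounds than are shown below. What is called first, only, known or untested is meant among the compounds shown, and "the series" means these compounds.

Three compounds built on a shared core were examined in a toxicity assay on THP-1 cells (Homo sapiens) for inhibition; a lower number here means that less compound is tolerated, a higher number that more compound is tolerated. Compound 1 `Cc1ccccc1-c1cnc(NC(=O)c2ccc(F)cc2)n1C` carries a 2-methylphenyl group, and compound 2 `Cc1cccc(-c2cnc(NC(=O)c3ccc(F)cc3)n2C)c1` differs from it in the core itself, as 2-methylphenyl in place of 3-methylphenyl on an aromatic carbon. In this assay compound 1 gives a limit rather than a number, > 50000 nM. Compound 2 likewise gives a limit, > 100000 nM. Compound 3 `Cn1c(-c2cccc([N+](=O)[O-])c2)cnc1NC(=O)c1ccc(F)cc1` carries a nitro group in place of the methyl of compound 2, described as nitro in place of methyl on an aromatic carbon, and in this assay compound 3 also stops at a limit, > 50000 nM. With every value a limit, the steps a step that the two limits leave unreadable from compound 1 to compound 2 and a step that the two limits leave unreadable from compound 2 to compound 3 cannot be read in size.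

Compound 4 `Cn1c(-c2ccccc2[N+](=O)[O-])cnc1NC(=O)c1ccc(F)cc1` has not yet been measured; it differs from compound 1 by nitro in place of methyl on an aromatic carbon. This is the same kind of change as that from compound 2 to compound 3, though the place differs: meta to a large group there, ortho to a large group here. The step that the limit leaves unreadable from compound 1 to compound 4 is expected to be small. That expectation rests on compound 1 sitting at the limit of > 50000 nM in this assay, at which 2 of the 3 values shown sit, and on the step that the two limits leave unreadable from compound 2 to compound 3 being unreadable in size. Compound 4 is therefore estimated at 80000 nM.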

Compound 4, half-maximal cytotoxic concentration: 31000 nM
Estimate against measurement, compound 4: 2.6-fold (0.41 log units) above, and the stated range covers the measured number.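

In this assay, nitro in place of methyl on an aromatic carbon, ortho to a large group, gives an at least 1.6-fold lower number from compound 1 to compound 4 (0.20 log units; that floor lies within the scatter), so the floor of this step does not by itself establish a change beyond the scatter. The same kind of change on the core of compound 2, leading to compound 3, runs between two limits, and neither that step nor the other step between limits can be read, so no size can be carried from one core to the other. The data therefore do not show whether the change has the same size, or even the same direction, on both cores, since only compound 4 gives a number while the comparison rests on a limit: the limit of > 50000 nM in this assay, at which 2 of the 4 values shown sit.

The compounds shown leave open how an amine or a carboxylic acid in place of the methyl would fare in this assay. They also leave open how large the steps hidden behind the limits are.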